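The source may hold more compounds than are shown below. What is called first, only, known or untested is meant among the compounds shown, and "the series" means these compounds.

Measured compounds:
compound 1, `CNc1cc(Oc2ccc(NC(=O)Nc3cccc(C)c3)cc2)ncn1`, 1260 nM in an assay on isolated protein for inhibition of serine/threonine-protein kinase TNNI3K (Homo sapiens); a higher number here means a weaker inhibitor, a lower number a stronger inhibitor
compound 2, `CNc1cc(Oc2ccc(NC(=O)Nc3cccc(C(F)F)c3)cc2)ncn1`, 100 nM in this assay
compound 3, `CNc1cc(Oc2ccc(NC(=O)Nc3cccc(CF)c3)cc2)ncn1`, 400 nM in this assay

Compound 3 stands second highest of the three numbers: in this assay it lies below compound 1 by a 3.2-fold lower number from compound 1 to compound 3 (0.50 log units; beyond the scatter) and above compound 2 by a 4.0-fold higher number from compound 2 to compound 3 (0.60 log units; beyond the scatter). The unmeasured compound 4, `CNc1cc(Oc2ccc(NC(=O)Nc3cccc(C(C)F)c3)cc2)ncn1`, differs from compound 3 in one place: methyl in place of hydrogen on a saturated chain carbon bound to an aromatic carbon and a fluorine atom. The three measured steps all concern fluorine on that same chain carbon: a 13-fold lower number from compound 1 to compound 2 (1.10 log units; beyond the scatter) and a 3.2-fold lower number from compound 1 to compound 3 (0.50 log units; beyond the scatter) both lower the number, while a 4.0-fold higher number from compound 2 to compound 3 (0.60 log units; beyond the scatter) raises it. None of them adds a carbon to that position, so the step to compound 4 has no direct precedent among these compounds. With the fluorine retained, the number for compound 4 is expected to stay close to that of compound 3, with the step of a 1.1-fold lower number from compound 3 to compound 4 (0.06 log units; within the scatter) estimated to lie within the scatter or a little beyond it in either direction. Compound 4 is therefore estimated at 350 nM in this assay, within a range from 120 nM to 1000 nM.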

Compound 4, half-maximal inhibitory concentration: 79 nM
For compound 4 the middle estimate is 4.4-fold (0.65 log units) above the measured one; measured number outside the range, below it.
By their numbers in this assay, from the lowest: compounds 4 and 2 (each within the scatter of the next); then compound 3; then compound 1.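

In this assay, the methyl on the carbon already bearing fluorine gives a 5.1-fold lower number from compound 3 to compound 4 (0.70 log units; beyond the scatter), so this carbon responds to an added carbon as well as to added fluorine. Swapping the second fluorine of the difluoromethyl group for that methyl gives a 1.3-fold lower number from compound 2 to compound 4 (0.10 log units; within the scatter), so the two groups cannot be told apart here, and both sit well below the plain methyl group, with a 16-fold lower number from compound 1 to compound 4 (1.20 log units; beyond the scatter). Nothing available explains why the added methyl has this effect.

An ethyl group at this place would show whether the gain from the added methyl depends on the fluorine. A trifluoromethyl group or a longer chain such as 1-fluoropropyl would show whether the number keeps falling as this carbon gains further fluorine or carbon.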